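Working notes: hexyloxy-to-methyl exchange, three measured compounds

The compounds below may be only part of what the source reports. "The series", "measured", "known", "first", "only" and "open" are said of these compounds alone.

Measured so far in a physicochemical assay for lipophilicity; a lower number here means a more polar compound, a higher number a more lipophilic compound:
compound 1 , `CCCCCCOc1ccc2[nH]c(-c3ccc(OC)cc3)c(C3=C(Br)C(=O)NC3=O)c2c1`: 4.1
compound 2 , `COc1ccc(-c2[nH]c3ccc(C)cc3c2C2=C(Br)C(=O)NC2=O)cc1`: 2.85
compound 3 , `CCCCCCOc1ccc2[nH]c(-c3cccc(OC)c3)c(C3=C(Br)C(=O)NC3=O)c2c1`: 3.92

Compound 1 and compound 3 have the same atoms joined differently: 3-methoxyphenyl in place of 4-methoxyphenyl on an aromatic carbon. In this assay this gives a number 0.18 log units lower from compound 1 to compound 3 (within the scatter). Compound 1 and compound 2 differ by methyl in place of hexyloxy on an aromatic carbon, which gives a number 1.25 log units lower from compound 1 to compound 2 (beyond the scatter).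

Compound 4 , `COc1cccc(-c2[nH]c3ccc(C)cc3c2C2=C(Br)C(=O)NC2=O)c1`, is not yet measured in this assay. It differs from compound 3 by methyl in place of hexyloxy on an aromatic carbon. The place is described in the same words as for the change between compound 1 and compound 2, so this is the same change, made here on the core of compound 3 rather than the core of compound 1.

Among the measured compounds shown here, for compound 4 the step is expected to be a number 1.25 log units lower from compound 3 to compound 4 (beyond the scatter), resting on the one measured instance of this change, a number 1.25 log units lower from compound 1 to compound 2 (beyond the scatter), applied to the value of compound 3 , 3.92. Compound 4 is therefore estimated at 2.67, between 2.3 and 3.05.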

Compound 4, partition coefficient: 3.12
For compound 4 the middle estimate is 0.45 log units below the measured one, and the stated range ends below it.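

In this assay, methyl in place of hexyloxy gives a number 0.80 log units lower from compound 3 to compound 4 (beyond the scatter), in the same direction as a number 1.25 log units lower from compound 1 to compound 2 (beyond the scatter), so the direction carries from one core to the other, while the size, modest here and large there, does not carry unchanged. The exchange of 3-methoxyphenyl for 4-methoxyphenyl gives a number 0.27 log units higher from compound 2 to compound 4 (within the scatter), so on the methyl core, as on the hexyloxy core, this exchange stays within the scatter. Two cores give no rule for the series, and nothing available accounts for the difference in step size.

Still open, going by these compounds, is how the number moves with a chain of intermediate length, such as butoxy, in place of hexyloxy. Also open, on these data alone, is whether the same carrying holds for an amine or a carboxylic acid at that place.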